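This account rests on a few compounds, and the source may have more. Where it says the series, first, only, none or still open, it means among the compounds named here.

For the measured compounds named here, in a functional assay on DU-145 cells (Homo sapiens) for cytotoxicity, read by MTT assay, with stated times of 48 h and 4 h (on this read-out higher numbers stand for weaker inhibition and lower numbers for stronger inhibition), compound 2 (`CCN(CC)CCCNc1nc(/C=C/c2ccc([N+](=O)[O-])cc2)nc2ccccc12`) gives 12300 nM, the only actual number so far. Compound 1 (`O=[N+]([O-])c1ccc(/C=C/c2nc(NCCN3CCCCC3)c3ccccc3n2)cc1`) reads > 100000 nM, which is a limit of the assay and not a number.

Compound 3 (`NCCCCNc1nc(/C=C/c2ccc([N+](=O)[O-])cc2)nc2ccccc12`) differs from compound 2 by aminomethyl in place of diethylamino on a saturated chain carbon, three bonds along the chain from a nitrogen on an aromatic ring. The same difference reads 3-(diethylamino)propyl to 4-aminobutyl, so the change falls at the amine end of the chain.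

Going by the values given here, the one measured step that bears on it is an at least 8.1-fold lower number from compound 1 to compound 2 (0.91 log units; beyond the scatter), and its true size stays open because of the limit of > 100000 nM in this assay, at which 1 of the 2 values shown sits. That step also changed the amine end of the chain, and it shows that a change there can move the number beyond the scatter. It is a different replacement, however, so it gives only weak guidance on direction. A modest step towards a higher number is expected in this assay, with no step beyond the scatter still possible.

The estimated change is a 2.4-fold higher number from compound 2 to compound 3 (0.39 log units; beyond the scatter). For compound 3 the expected value is 30000 nM, with an estimated range of 7000 nM to 100000 nM.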

Compound 3, half-maximal inhibitory concentration: 4150 nM
Compound 3: the middle estimate sits 7.2-fold (0.86 log units) above what was measured; measured number outside the range, below it.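

In this assay, 4-aminobutyl in place of 3-(diethylamino)propyl gives a 3.0-fold lower number from compound 2 to compound 3 (0.47 log units; beyond the scatter), so the change at the amine end of the chain goes towards stronger inhibition. The earlier step showed only that this end of the chain can move the number; this one shows that the diethylamino group is not required for the activity seen so far, since the compound with an unsubstituted amino end reads lower. With 2-aminoethyl in place of piperidin-1-yl, the series shows an at least 24-fold lower number from compound 1 to compound 3 (1.38 log units; beyond the scatter), but the value of compound 1 is a limit and not a number, and the true size of this step stays open because of it: the limit of > 100000 nM in this assay, at which 1 of the 3 values shown sits.

The step to compound 3 alters both the length of the chain and the substitution on its terminal amine, so the compounds shown do not separate these two contributions. From the compounds shown here alone, how a 3-aminopropyl chain or a 4-(diethylamino)butyl chain would read on the shared core remains open, and this would be the direct way to tell them apart.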